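The compounds below may be only part of what the source reports. "The series", "measured", "known", "first", "only" and "open" are said of these compounds alone.

Three compounds have so far been measured in an ADME assay on HEK293 cells (Homo sapiens) for cytotoxicity, with a stated time of 72 h; on this read-out higher numbers stand for an effect only at larger amounts of compound and lower numbers for an effect already at smaller amounts:

Compound 1, `Cc1cc(NC(=O)Nc2ccccc2F)c2ccccc2n1`, gives only a limit of the assay, > 25000 nM.
Compound 2, `Cc1cc(NC(=O)Nc2cccc(Cl)c2)c2ccccc2n1`, gives 21000 nM.
Compound 3, `COC(=O)c1ccc(NC(=O)Nc2cc(C)nc3ccccc23)cc1`, gives 15000 nM.

Compound 3 and compound 2 therefore sit within the usual scatter of each other, and compound 1 offers no number, only the limit (the limit of > 25000 nM in this assay, at which 1 of the 3 values shown sits). All three share the same core and differ only in the group on the second aromatic ring of the urea.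

Compound 4, `Cc1cc(NC(=O)Nc2ccc(Cl)cc2)c2ccccc2n1`, differs from compound 3 in one place: chloro in place of methoxycarbonyl on an aromatic carbon. Within the data shown here, the only measured step that touches this part of the molecule is an at least 1.1-fold lower number from compound 1 to compound 2 (0.07 log units; that floor lies within the scatter), a change of the same kind, and it stayed within the scatter. A substituent change on this ring has thus given no clear movement so far, and nothing in the data points to compound 4 behaving otherwise. The step expected from compound 3 to compound 4 is therefore a 1.2-fold higher number from compound 3 to compound 4 (0.08 log units; within the scatter), which is no change beyond the scatter. Compound 4 is estimated to give 18000 nM, in a range from 9000 nM to 36000 nM.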

Compound 4, half-maximal effective concentration: > 25000 nM
Compound 4: no number, only a limit; the forecaster's own chance of this, stated with the estimate: 30%; middle value at least 1.3-fold (0.14 log units) away from the limit.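

In this assay compound 4 gives only a limit, > 25000 nM, and with it another compound now stands at that limit: the limit of > 25000 nM in this assay, at which 2 of the 4 values shown sit.

Putting chloro in place of methoxycarbonyl, para to a large group, gives an at least 1.6-fold higher number from compound 3 to compound 4 (0.22 log units; that floor lies within the scatter), so this change has a floor that can be read but no top, and the data cannot say whether its true size lies beyond the scatter. Shifting the chlorine from the 3-chlorophenyl group to the 4-chlorophenyl group gives an at least 1.1-fold higher number from compound 2 to compound 4 (0.07 log units; that floor lies within the scatter), which likewise shows no clear effect of where the chlorine sits, and the step between the two compounds that both stand at the limit cannot be read.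

Going by these compounds, what stays open is whether any group at this position can move the number clearly beyond the scatter, in either direction. An amine or a carboxylic acid in place of the chloro of compound 4 would put that question to groups quite unlike chloro and methoxycarbonyl, and the compounds shown give no hint of the answer.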